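Dropping One Methoxy Group: Little Change Expected

The source may report more compounds than this note shows. Statements on the series, on what has been measured and on what is new or still open speak of the compounds shown alone.

Compound 1 `COc1ccc(-c2cc(/C=C/C(=O)c3ccc(N)cc3)[nH]n2)cc1` and compound 2 `COc1cc(-c2cc(/C=C/C(=O)c3ccc(N)cc3)[nH]n2)cc(OC)c1OC` share a core and differ only in how many methoxy groups they carry. In a functional assay on CCRF-CEM cells (Homo sapiens) for cytotoxicity, read by sulforhodamine B assay, with a stated time of 48 h, tested at 0.01 uM (a lower number here means a stronger effect, a higher number a weaker effect of the compound at the concentration tested), compound 1 gives 99%, and in this assay compound 2 gives 96%. Compound 2 has the lower of the two numbers, but its gap to compound 1 lies within the scatter of repeated measurements, so the two compounds cannot be told apart on these numbers.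

Compound 3 `COc1ccc(-c2cc(/C=C/C(=O)c3ccc(N)cc3)[nH]n2)cc1OC` has not yet been measured. It differs from compound 2 in one place: hydrogen in place of methoxy on an aromatic carbon. Among the measured compounds shown here, no step between two measured compounds isolates this change, so its size has no measured guide. Since compound 1 with 99% and compound 2 with 96% already sit within the scatter of each other, the expected step is a number 1 percentage points higher from compound 2 to compound 3 (within the scatter), none beyond the scatter. Compound 3 is estimated to give 97% in this assay, with a range from 90% to 103%.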

Compound 3, a percentage reported as activity, at one concentration (the size of the read-out at that concentration, not a potency): 97%
The estimate for compound 3 equals the measured number at the digits printed; low and high end bracket the measured number.
By their numbers in this assay, from the lowest: compounds 2, 3 and 1 (each within the scatter of the next).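

Removing one methoxy group from an aromatic carbon of compound 2, at the place ortho to a methoxy group, now has a measured size in this assay: the step is a number 1 percentage points higher from compound 2 to compound 3 (within the scatter) on that change. The neighbouring change, methoxy in place of hydrogen on an aromatic carbon, also has a measured size, with a step of a number 2 percentage points lower from compound 1 to compound 3 (within the scatter) on the way to the same compound. Neither single change can be told apart from the scatter, so at this one tested concentration, these methoxy changes do not separate the compounds.

On these data alone, whether a different group on this carbon, such as a carboxylic acid or a longer ether chain, would move the number beyond the scatter stays open. Nothing measured here gives a reason for the size of these steps.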